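Amide aryl substituent change in the benzamide-piperidine series

This account rests on a few compounds, and the source may have more. Where it says the series, first, only, none or still open, it means among the compounds named here.

Of the compounds shown here, two have been measured. Compound 1 `O=C(c1ccc(Cl)c(C(F)(F)F)c1)N1CCC(n2cncc2-c2ccc(OS(=O)(=O)c3cccc4cnccc34)cc2)CC1` gives 45 nM in an assay on HEK293 cells for antagonist activity at P2X purinoceptor 7 (Homo sapiens), read by fluorescence, with a stated time of 2 h; on this read-out lower numbers stand for stronger inhibition and higher numbers for weaker inhibition. Compound 2 `CN(C)c1ccc(C(=O)N2CCC(n3cncc3-c3ccc(OS(=O)(=O)c4cccc5cnccc45)cc3)CC2)cc1` gives 0.11 nM in this assay and stands lowest of the two numbers; its nearest neighbour is compound 1, reached by a 410-fold lower number from compound 1 to compound 2 (2.61 log units; beyond the scatter), a change of the aryl group on the carbonyl carbon that is well beyond the scatter. Compound 3 `CC(C)c1ccc(C(=O)N2CCC(n3cncc3-c3ccc(OS(=O)(=O)c4cccc5cnccc45)cc3)CC2)cc1` is not yet measured. It differs from compound 2 only in isopropyl in place of dimethylamino on an aromatic carbon. Among the compounds with values here, no measured step covers this exact exchange; the one step that bears on it, a 410-fold lower number from compound 1 to compound 2 (2.61 log units; beyond the scatter), shows that altering the substituents on this aryl ring can move the number by a very large amount, with the dimethylamino-bearing ring giving the lowest number seen. Isopropyl shares no atom type beyond carbon with dimethylamino, so a move back toward higher numbers is expected for compound 3, though its size is uncertain and smaller than the step from compound 1 to compound 2. Compound 3 is expected at 1.5 nM, within 0.2 nM to 15 nM, corresponding to a 14-fold higher number from compound 2 to compound 3 (1.13 log units; beyond the scatter).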

Compound 3, half-maximal inhibitory concentration: 55 nM
Compound 3: middle estimate off by 37-fold (1.56 log units), on the low side; measured number outside the range, above it.
By their numbers in this assay, from the lowest: compound 2; then compounds 1 and 3 (each within the scatter of the next).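

In this assay the exchange of dimethylamino for isopropyl, on an aromatic carbon para to a large group, gives a 500-fold higher number from compound 2 to compound 3 (2.70 log units; beyond the scatter): the two groups have the same heavy-atom count, and they differ in one nitrogen for one carbon and in the one hydrogen-bond acceptor counted for dimethylamino. With a 1.2-fold higher number from compound 1 to compound 3 (0.09 log units; within the scatter), the 4-isopropylphenyl and 4-chloro-3-(trifluoromethyl)phenyl amides cannot be told apart in this read-out, so among these three compounds the low number appears only with the 4-(dimethylamino)phenyl group of compound 2, and the two other aryl groups do not form a graded series with it. No measurement on hand accounts for this step.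

The compounds shown leave open whether the low number needs dimethylamino itself or also comes with another group at this place, such as an amino group, a methoxy group, a diethylamino group or a pyrrolidine ring. They also leave open whether dimethylamino keeps this effect on another carbon of the ring, or when the rest of the core of compound 2 is changed.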